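A few compounds are considered here, and "the series" means these few. Any claim that something is new, unique, unknown or untested is made for them only; others in the source may bear on it.

Of the compounds shown here, three with a shared core have been tested, and a fourth awaits its number. Compound 1 `COc1ncc(-c2ccc3c(c2)N(C2CCCCC2)C(=O)CO3)cc1NS(=O)(=O)c1ccc(F)cc1` and compound 2 `COc1ccc(N2C(=O)COc3ccc(-c4cnc(OC)c(NS(=O)(=O)c5ccc(F)cc5)c4)cc32)cc1` differ in one place only, and so do compound 3 `COc1ccc(N2C(=O)COc3ccc(-c4cccc(NS(=O)(=O)c5ccc(F)cc5)c4)cc32)cc1` and compound 4 `O=C1COc2ccc(-c3cccc(NS(=O)(=O)c4ccc(F)cc4)c3)cc2N1C1CCCCC1`. The cores of compound 2 and compound 3 differ as well, but that difference between the two cores is not broken down here.

In a functional assay on HeLa cells (Homo sapiens) for antiproliferative activity, read by MTT assay, with a stated time of 72 h (a higher number here means a weaker inhibitor, a lower number a stronger inhibitor), compound 2 gives 1220 nM. Compound 1 gives 6100 nM, and compound 3 gives 13200 nM, the highest of the three numbers.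

The change from compound 2 to compound 1 is cyclohexyl in place of 4-methoxyphenyl on an amide-type nitrogen in a ring. It made a 5.0-fold higher number from compound 2 to compound 1 (0.70 log units; beyond the scatter). The change from compound 3 to compound 4 is cyclohexyl in place of 4-methoxyphenyl on an amide-type nitrogen in a ring; the place described is the same word for word, so this is the same change made on a different core.

Within the data shown here, with only one earlier example of this change, the expectation for compound 4 rests on that single step. Compound 4 is expected to give 55000 nM, with 18000 nM to 170000 nM as the likely span, because the same change gave a 5.0-fold higher number from compound 2 to compound 1 (0.70 log units; beyond the scatter). That expectation means a step of a 4.2-fold higher number from compound 3 to compound 4 (0.62 log units; beyond the scatter), similar in size to the earlier one. Whether a different core changes the size of the step is not known from these three compounds, and the estimate is held wide for that reason.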

Compound 4, half-maximal inhibitory concentration: 10800 nM
Compound 4: the middle estimate sits 5.1-fold (0.71 log units) above what was measured; measured number outside the range, below it.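

In this assay, putting cyclohexyl in place of 4-methoxyphenyl on the amide-type nitrogen in a ring gives a 1.2-fold lower number from compound 3 to compound 4 (0.09 log units; within the scatter), so on this core the swap has no effect that can be told apart from the ordinary variation between repeated measurements. The same swap therefore does not carry over at the same size from one core to the other: the same change on two cores in this assay, a 5.0-fold higher number (0.70 log units; beyond the scatter) from compound 2 to compound 1 and a 1.2-fold lower number (0.09 log units; within the scatter) from compound 3 to compound 4, 6.1-fold (0.79 log units) apart, beyond the scatter of two such steps. This shows that, for these two pairs, a step measured on one core is a poor guide to the step on the other, but it does not show which part of the cores makes the difference, and two cores are too few to give a rule for any further core.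

Going by these compounds, only 4-methoxyphenyl and cyclohexyl appear on this nitrogen, so it remains open how a group carrying an amine or a carboxylic acid, or a longer carbon chain, would behave there on either core. On these data alone, it is also open whether the size of the step on a third core would resemble the step on the core of compound 1 or the step on the core of compound 3.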